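Methyl on the pyrrolidine: a small step from compound 1

The source may hold more compounds than are shown below. What is called first, only, known or untested is meant among the compounds shown, and "the series" means these compounds.

Measured compounds:
compound 1, `Cn1c(N2CCCC2)c(C#N)c2c(N)ncnc21`, 125 nM
compound 2, `C[C@@H]1CCCN1c1c(C#N)c2c(N)nc(Nc3cnn(C)c3)cc2n1C`, 794 nM
compound 3, `C[C@@H]1CCCN1c1cc2c(N)ncnc2n1C`, 439 nM

All three were tested in an assay on isolated protein for binding affinity to Leucine-rich repeat serine/threonine-protein kinase 2 variant G2019S (Homo sapiens), read by TR-FRET and LanthaScreen, with a stated time of 2 h; a lower number here means a stronger inhibitor, a higher number a weaker inhibitor. Among them compound 1 stands lowest: compound 3 gives a higher number, and compound 2 a higher one still, both gaps beyond the scatter. None of the three pairs differs in a single place, so the numbers show only where each stands, not what any one change does.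

Compound 4, `C[C@H]1CCCN1c1c(C#N)c2c(N)ncnc2n1C`, has not yet been measured. It is compound 1 with one change: methyl in place of hydrogen on a saturated ring carbon. Compound 3 carries the same methylpyrrolidine yet lacks the nitrile of compound 1, and compound 2 carries it together with a further substituent, so neither gives a clean reading of the methyl alone.

For compound 4 the step of a 1.6-fold higher number from compound 1 to compound 4 (0.20 log units; within the scatter) is expected to be small, inside or near the scatter, with no clear direction. Compound 4 is therefore estimated at 200 nM, within a range from 60 nM to 700 nM.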

Compound 4, inhibition constant: 212 nM
Compound 4: middle estimate off by 1.1-fold (0.03 log units), on the low side, and the stated range covers the measured number.
By their numbers in this assay, from the lowest: compounds 1 and 4 (each within the scatter of the next); then compounds 3 and 2 (each within the scatter of the next).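

In this assay, within the data shown here, going from pyrrolidin-1-yl to 2-methylpyrrolidin-1-yl gives a 1.7-fold higher number from compound 1 to compound 4 (0.23 log units; within the scatter), and this is the first clean reading of the methyl on its own, as compound 2 and compound 3 carry a methylpyrrolidine alongside other differences from compound 1. It shows that this saturated ring carbon, next to the ring nitrogen, can bear a methyl in place of hydrogen with no change that stands clear of the scatter, so compound 1 and compound 4 cannot be ranked against each other. Nothing measured here on the compounds gives a cause for this result, and none can be assigned to it.

As far as these compounds go, this single pair does not show how much room the position has, so it remains open whether an ethyl, a hydroxymethyl or a dimethylamino group on the same ring carbon would also stay within the scatter of compound 1. Also open is whether the mirror-image arrangement of the methyl on the core of compound 4 would read the same, since the one pair shown covers a single arrangement.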